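The source may hold more compounds than are shown below. What is called first, only, known or untested is meant among the compounds shown, and "the series" means these compounds.

In a functional assay on BJAB cells (Homo sapiens) for antiproliferative activity, with a stated time of 4 days (a lower number here means that less compound is needed, a higher number that more compound is needed for the effect), compound 1 `Cc1c(-c2cc(Cl)cc(Cl)c2)c(C(=O)O)nn1-c1nc(-c2cccnc2)c(SC(C)C)s1` gives "not active" (no number reported), so no number is available for it. Among the compounds with values here, compound 2 `Cc1nn(-c2nc(-c3ccc(Cl)c(Cl)c3)c(SC(C)C)s2)c(C(=O)O)c1-c1cccc(Cl)c1C` gives 5100 nM in this assay, the only number so far, and compound 2 therefore stands alone as the reference point. Compound 3 `Cc1nn(-c2nc(-c3ccc(Cl)c(Cl)c3)c(SC(C)C)s2)c(C(=O)O)c1-c1ccccc1` is not yet measured; it differs from compound 2 by phenyl in place of 3-chloro-2-methylphenyl on an aromatic carbon. Within the data shown here, with no measured step of this kind to lean on, the expected change is a modest loss, a 1.8-fold higher number from compound 2 to compound 3 (0.25 log units; within the scatter), possibly still within the scatter. Compound 3 is thus estimated at 9000 nM in this assay, between 3000 nM and 30000 nM.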

Compound 3, half-maximal effective concentration: 3000 nM
Beside the measured number, compound 3's estimate is 3.0-fold (0.48 log units) above it; the measured number falls inside the stated range.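

Phenyl in place of 3-chloro-2-methylphenyl on this aromatic carbon, which bears its ring between the carboxy and methyl groups' ring atoms, gives a 1.7-fold lower number from compound 2 to compound 3 (0.23 log units; within the scatter) in this assay and leaves the two compounds indistinguishable. For this pair, then, the chloro and methyl substituents on the ring at this position are not required for a number of this size.

Going by these compounds, whether a methoxy group or an amine on that phenyl ring, or a short alkyl chain in place of the ring, would shift the number stays open. No measurement at hand explains the result.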